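This account rests on a few compounds, and the source may have more. Where it says the series, first, only, none or still open, it means among the compounds named here.

Measured so far in a functional assay on HeLa cells (Homo sapiens) for antiproliferative activity, read by cell counting, with a stated time of 72 h; a higher number here means a weaker inhibitor, a lower number a stronger inhibitor:

Compound 1, `C#C[C@@]1(O)[C@@H](CO)O[C@@H](n2cc(Cl)c3c(N)ncnc32)[C@@H]1O`: 51 nM
Compound 2, `C#C[C@@]1(O)[C@@H](CO)O[C@@H](n2cc(Br)c3c(N)ncnc32)[C@@H]1O`: 93 nM
Compound 3, `C#C[C@@]1(O)[C@@H](CO)O[C@@H](n2cc(Cl)c3c(Cl)ccnc32)[C@@H]1O`: 6300 nM

Compounds 1 and 2 differ only by bromo in place of chloro on an aromatic carbon. That change gave a 1.8-fold higher number from compound 1 to compound 2 (0.26 log units; within the scatter), so the two values are not separated here. Compound 3 carries a different core; how the two cores differ is not broken down here. Its value in this assay stands well apart from those of compound 1 and compound 2.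

Compound 4, `C#C[C@@]1(O)[C@@H](CO)O[C@@H](n2cc(Br)c3c(Cl)ccnc32)[C@@H]1O`, is not yet measured. It differs from compound 3 by bromo in place of chloro on an aromatic carbon, the same change as from compound 1 to compound 2, made at the same place. On that single precedent the step is expected to be small, about a 1.7-fold higher number from compound 3 to compound 4 (0.24 log units; within the scatter). Compound 4 is therefore estimated at 11000 nM, with a likely range from 4000 nM to 30000 nM.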

Compound 4, half-maximal inhibitory concentration: 890 nM
Beside the measured number, compound 4's estimate is 12-fold (1.09 log units) above it; measured number outside the range, below it.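

In this assay, bromo in place of chloro on an aromatic carbon gives a 7.1-fold lower number from compound 3 to compound 4 (0.85 log units; beyond the scatter), and this step does not match the one on the other core: the same change on two cores in this assay, a 1.8-fold higher number (0.26 log units; within the scatter) from compound 1 to compound 2 and a 7.1-fold lower number (0.85 log units; beyond the scatter) from compound 3 to compound 4, 13-fold (1.11 log units) apart, beyond the scatter of two such steps

Within these two pairs, the outcome of the change therefore depends on the core, and a step read on one core is a poor guide to the other. Two pairs do not show which difference between the cores matters, nor how the change would behave on a further core.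

The compounds shown carry only chloro or bromo at this place, leaving iodo, methyl and nitrile there open. Going by these compounds, whether such groups would follow compound 1 and compound 2 or compound 3 and compound 4 is also open.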